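Hydroxy in Place of Pentylamino on the Shared Core

This account rests on a few compounds, and the source may have more. Where it says the series, first, only, none or still open, it means among the compounds named here.

Compound 1 `COc1ccc(Cn2c(O)nc3c(N)ncnc32)cc1`: 10 uM
Compound 2 `CCCCCNc1nc(N)c2nc(O)n(Cc3ccccc3)c2n1`: 0.1 uM
Compound 3 `Nc1ncnc2c1nc(O)n2Cc1ccc(F)cc1`: 10 uM

In a functional assay (spleen, spleen) for activation, with Mus musculus as the target (a higher number here means that more compound is needed for the effect, a lower number that less compound is needed), compound 2 stands lowest of the three numbers, with compound 1 and compound 3 both well beyond the scatter above it. Compound 4 `Nc1nc(O)nc2c1nc(O)n2Cc1ccccc1` differs from compound 2 by hydroxy in place of pentylamino on an aromatic carbon. Among the compounds with values here, the one measured step, no change at the digits printed from compound 1 to compound 3 (within the scatter), concerns the benzyl ring and does not bear on this change. Within the data shown here, no measured pair isolates the pentylamino group: compound 1 and compound 3 lack it but differ from compound 2 in two places, so their values alone suggest its loss costs much. Compound 4 is therefore expected to give 10 uM, within 1 uM to 30 uM. The expected step is a 100-fold higher number from compound 2 to compound 4 (2.00 log units; beyond the scatter).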

Compound 4, minimum effective concentration: 0.1 uM
Estimate against measurement, compound 4: 100-fold (2.00 log units) above; the measured number lies below the stated range.
By their numbers in this assay, from the lowest: compounds 2 and 4 (each within the scatter of the next); then compounds 1 and 3 (each within the scatter of the next).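

In this assay, hydroxy in place of pentylamino on the aromatic carbon between two ring nitrogen atoms gives no change at the digits printed from compound 2 to compound 4 (within the scatter). The pentylamino chain is therefore not required at this position for the number of compound 2, which compound 1 and compound 3, each differing from compound 2 in two places, could not show. Nothing available explains this outcome. The compounds shown leave open whether a methoxy group or a longer chain at this position would give the same number. Also open, going by these compounds, is what a plain hydrogen there gives with an unsubstituted benzyl ring, as compound 1 and compound 3 carry it only with a substituted one.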